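The source may report more compounds than this note shows. Statements on the series, on what has been measured and on what is new or still open speak of the compounds shown alone.

Of the compounds shown here, two that share one core have been measured so far in an ADME assay on WI-38 cells (Homo sapiens) for cytotoxicity, read by MTT assay, with a stated time of 3 days; a higher number here means a weaker inhibitor, a lower number a stronger inhibitor. Compound 1 `CCCCCCC#Cc1cn(C/C=C/CN2C(=O)c3ccccc3C2=O)c(=O)[nH]c1=O` gives 40000 nM, and compound 2 `CCCCCc1ccc(C#Cc2cn(C/C=C/CN3C(=O)c4ccccc4C3=O)c(=O)[nH]c2=O)cc1` gives 25000 nM. These two numbers lie within the scatter of each other, so compound 2 cannot be told apart from compound 1 on this measure.

The next structure is compound 3 `O=C1c2ccccc2C(=O)N1C/C=C/Cn1cc(C#CCCc2ccccc2)c(=O)[nH]c1=O`, which keeps the core of compound 2 and changes one group on a triple-bonded carbon: phenethyl in place of 4-pentylphenyl (phenethyl in place of 4-pentylphenyl on a triple-bonded carbon). Among the measured compounds shown here, only one measured step bears on this change. That step is a 1.6-fold lower number from compound 1 to compound 2 (0.20 log units; within the scatter), and it swapped 4-pentylphenyl for hexyl on the same triple-bonded carbon. It stayed within the scatter, although it is thin evidence on its own.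

On that basis, no step beyond the scatter is expected in this assay, and the direction cannot be called. The expected change is small, a 1.2-fold higher number from compound 2 to compound 3 (0.08 log units; within the scatter). Compound 3 is estimated at 30000 nM, with an expected range of 15000 nM to 60000 nM.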

Compound 3, half-maximal inhibitory concentration: 31000 nM
For compound 3 the middle estimate is 1.0-fold (0.01 log units) below the measured one; the measured number falls inside the stated range.
By their numbers in this assay, from the lowest: compounds 2, 3 and 1 (each within the scatter of the next).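

In this assay, replacing 4-pentylphenyl with phenethyl on a triple-bonded carbon gives a 1.2-fold higher number from compound 2 to compound 3 (0.09 log units; within the scatter), so exchanging one group holding one six-membered aromatic ring of carbon only for another such group does not separate these two compounds. The second new comparison, phenyl in place of butyl on a saturated chain carbon, two bonds along the chain from a triple-bonded carbon, gives a 1.3-fold lower number from compound 1 to compound 3 (0.11 log units; within the scatter), so a ring at the end of the chain likewise makes no measurable difference here. Across hexyl, 4-pentylphenyl and phenethyl, this position has therefore produced no step beyond the scatter, and no supporting measurement offers an explanation for that.

All three groups are built from carbon and hydrogen alone, so these compounds cannot show whether an amine or a carboxylic acid on the same triple-bonded carbon would give a number clearly apart from the others. A group as small as methyl also remains an open case at this position.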